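The compounds below may be only part of what the source reports. "The series", "measured", "known", "first", "only" and "open" are said of these compounds alone.

In a functional assay on MCF7 cells (Homo sapiens) for inhibition, read by resazurin assay, with a stated time of 24 h (a lower number here means a stronger inhibitor, a higher number a weaker inhibitor), three compounds sharing one core differ only in the aryl group on a saturated ring carbon. Compound 1 `O=C1Nc2c(C(F)(F)F)cccc2C1(c1ccc(OC(F)(F)F)cc1)c1c(F)cc(O)cc1F`, carrying 2,6-difluoro-4-hydroxyphenyl, gives 549 nM. Compound 2 `O=C1Nc2c(C(F)(F)F)cccc2C1(c1ccc(OC(F)(F)F)cc1)c1ccc(OC(F)(F)F)cc1`, carrying 4-(trifluoromethoxy)phenyl, gives > 1000 nM, which is a limit of the assay and not a number. Compound 3 `O=C1Nc2c(C(F)(F)F)cccc2C1(c1ccc(OC(F)(F)F)cc1)c1ccc(O)c(O)c1`, carrying 3,4-dihydroxyphenyl, gives 49 nM, the lowest number of the three. Both steps to it are large: an 11-fold lower number from compound 1 to compound 3 (1.05 log units; beyond the scatter), and an at least 20-fold lower number from compound 2 to compound 3 (1.30 log units; beyond the scatter).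

Compound 4 `Cc1cc(C2(c3ccc(OC(F)(F)F)cc3)C(=O)Nc3c(C(F)(F)F)cccc32)cc(C)c1O` has not yet been measured. It has 4-hydroxy-3,5-dimethylphenyl in place of 3,4-dihydroxyphenyl on a saturated ring carbon. Among the measured compounds shown here, no measured step makes this exact exchange, but all of them change the same place. The closest guide is compound 1, which also has a 4-hydroxy group with two further groups on the ring, and the step of an 11-fold lower number from compound 1 to compound 3 (1.05 log units; beyond the scatter) separates it from compound 3. The larger step of an at least 20-fold lower number from compound 2 to compound 3 (1.30 log units; beyond the scatter) involves a ring without any hydroxy group, which compound 4 does not share. A higher number is therefore expected in this assay, probably by a smaller margin than compound 1 shows. The expected step is a 4.1-fold higher number from compound 3 to compound 4 (0.61 log units; beyond the scatter). Compound 4 is estimated at 200 nM, with an expected range from 60 nM to 700 nM.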

Compound 4, half-maximal inhibitory concentration: > 1000 nM
Compound 4: only a limit was reported (the forecaster's own chance of this, stated with the estimate: 12%); middle value at least 5.0-fold (0.69 log units) away from the limit.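

Exchanging 3,4-dihydroxyphenyl for 4-hydroxy-3,5-dimethylphenyl gives an at least 20-fold higher number from compound 3 to compound 4 (1.30 log units; beyond the scatter), so in this assay a hydroxy group on this aryl ring is not enough by itself to keep the number low at this saturated ring carbon. The comparison with the other ring that carries a 4-hydroxy group and two further groups says much less: an at least 1.8-fold higher number from compound 1 to compound 4 (0.26 log units; that floor lies within the scatter). It only sets a floor, and that floor does not separate the two rings. Compound 2 and compound 4 each stand at a limit of the assay and not at a number, so the step between them cannot be read: the limit of > 1000 nM in this assay, at which 2 of the 4 values shown sit.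

The compounds shown leave open whether the low number of compound 3, 49 nM, depends on both hydroxy groups of its ring or on that ring carrying no methyl or fluoro groups. Also open, from the compounds shown here alone, is how a methoxy group or an amine in place of one of those hydroxy groups would read in this assay.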